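A few compounds are considered here, and "the series" means these few. Any claim that something is new, unique, unknown or untested is made for them only; others in the source may bear on it.

Measured so far in a functional assay on THP-1 cells (Homo sapiens) for cytotoxicity, read by MTT assay, with a stated time of 24 h; a lower number here means a stronger inhibitor, a higher number a weaker inhibitor:
- compound 1 `COc1ccc(/C=C2\CN(C)C/C(=C\c3ccccc3F)C2=O)cc1OC`: 11200 nM
- compound 2 `COc1cc(/C=C2\CN(C)C/C(=C\c3ccccc3F)C2=O)cc(OC)c1OC`: 640 nM

Of the two measured compounds, compound 2 has the lower number, 640 nM, in this assay. The next compound to be measured is compound 3 `COc1cc(/C=C2\CN(C)C/C(=C\c3ccc(Cl)cc3)C2=O)cc(OC)c1OC`. It differs from compound 2 in one place: 4-chlorophenyl in place of 2-fluorophenyl on a double-bonded chain carbon bound to a double-bonded ring carbon. This puts 4-chlorophenyl in place of 2-fluorophenyl on a double-bonded chain carbon bound to a double-bonded ring carbon.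

For the measured compounds named here, only one measured step is available, an 18-fold lower number from compound 1 to compound 2 (1.24 log units; beyond the scatter). That step is large, but it is methoxy in place of hydrogen on an aromatic carbon, not a change at the place altered here. Going by the values given here, no measured step therefore gives the direction or size of this exchange. The large step does show that one change can move the number far in this series, which argues for a wide range. No step beyond the scatter is expected, and the estimated step is a 1.3-fold higher number from compound 2 to compound 3 (0.10 log units; within the scatter). For compound 3 the expected value is 800 nM, within an estimated range of 200 nM to 3500 nM.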

Compound 3, half-maximal inhibitory concentration: 7200 nM
Compound 3: middle estimate off by 9.0-fold (0.95 log units), on the low side; the measured number lies above the stated range.
By their numbers in this assay, from the lowest: compound 2; then compounds 3 and 1 (each within the scatter of the next).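

In this assay, for the compounds shown here, 4-chlorophenyl in place of 2-fluorophenyl on a double-bonded chain carbon bound to a double-bonded ring carbon gives an 11-fold higher number from compound 2 to compound 3 (1.05 log units; beyond the scatter), so this position, which had no measured step before, responds strongly to an exchange of one substituted phenyl group for another. The two groups have the same heavy-atom count, the same carbon-only aromatic ring, no hydrogen-bond donors or acceptors and no net charge, so these counts do not separate them, and the step has to be tied to the identity of the halogen, its location on the ring, or both. No measurement available for this series accounts for the size or direction of the step.

The exchange alters the halogen and its location together, so 4-fluorophenyl and 2-chlorophenyl at this position would be needed to tell those two changes apart. Also open, on these data alone, is how this position responds to an unsubstituted phenyl or to a phenyl carrying an amine or a carboxylic acid, and whether the step carries over to the core of compound 1.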